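Aryl variation in the series: estimating compound 4

The source may hold more compounds than are shown below. What is called first, only, known or untested is meant among the compounds shown, and "the series" means these compounds.

Measured so far, in a functional assay on the whole organism for inhibition, with Mythimna separata as the target, with a stated time of 5 days; a higher number here means that more compound is needed for the effect, a lower number that less compound is needed:
compound 1, `CC(C)(C)n1ncc(OCc2nnc(-c3cccc(F)c3)o2)c(Cl)c1=O`, gives 7100 nM;
compound 2, `CC(C)(C)n1ncc(OCc2nnc(-c3ccccc3)o2)c(Cl)c1=O`, gives 12200 nM;
compound 3, `CCc1ccc(-c2nnc(COc3cnn(C(C)(C)C)c(=O)c3Cl)o2)cc1`, gives 14500 nM.

Compound 3 gives the highest number shown; its gap to compound 2 is within the scatter, its gap to compound 1 is beyond it (a 2.0-fold higher number from compound 1 to compound 3 (0.31 log units; beyond the scatter)). Compound 4, `Cc1cccc(-c2nnc(COc3cnn(C(C)(C)C)c(=O)c3Cl)o2)c1`, differs from compound 3 by 3-methylphenyl in place of 4-ethylphenyl on an aromatic carbon. For the measured compounds named here, two measured steps bear on this: a 1.2-fold higher number from compound 2 to compound 3 (0.08 log units; within the scatter), within the scatter, and a 1.7-fold higher number from compound 1 to compound 2 (0.24 log units; within the scatter), also within the scatter. Nothing here separates one aryl group clearly from another, so for compound 4 no step beyond the scatter is expected, with at most a slightly lower number as a 1.5-fold lower number from compound 3 to compound 4 (0.16 log units; within the scatter). Compound 4 is estimated at 10000 nM, within 4000 nM to 25000 nM.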

Compound 4, half-maximal effective concentration: 116000 nM
The estimate for compound 4 lay 12-fold (1.06 log units) below the measured number, and the stated range ends below it.
By their numbers in this assay, from the lowest: compounds 1, 2 and 3 (each within the scatter of the next, the first and the last beyond it); then compound 4.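

On the five-membered aromatic ring, 3-methylphenyl stands apart in this assay from every earlier aryl group: against 4-ethylphenyl (an 8.0-fold higher number from compound 3 to compound 4 (0.90 log units; beyond the scatter)), against phenyl (a 9.5-fold higher number from compound 2 to compound 4 (0.98 log units; beyond the scatter)) and against 3-fluorophenyl (a 16-fold higher number from compound 1 to compound 4 (1.21 log units; beyond the scatter)). This aryl group therefore matters more than compounds 1 to 3 showed, and methyl in place of fluoro gives the largest step here, although 4-ethylphenyl and phenyl stay within the scatter of each other. Nothing available explains this jump.

From the compounds shown here alone, it remains open whether the high number belongs to methyl specifically or also to other groups on the phenyl ring. 3-Methoxyphenyl, 3-aminophenyl and 4-methylphenyl would show whether such groups follow compound 4 or compound 1.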